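Methoxy in place of fluoro on the aryl ether ring

The source may report more compounds than this note shows. Statements on the series, on what has been measured and on what is new or still open speak of the compounds shown alone.

Compound 1 `Cc1ccc(Nc2nc(N)nc(COc3cccc(N4CCCC4=O)c3)n2)cc1Cl` gives 820 nM in an assay on COS-7 cells for agonist activity at Free fatty acid receptor 1 (Homo sapiens), read by scintillation counting and inositol phosphate accumulation, with a stated time of 90 min; a higher number here means that more compound is needed for the effect, a lower number that less compound is needed. Its fluoro analogue, compound 2 `Cc1ccc(Nc2nc(N)nc(COc3cc(F)cc(N4CCCC4=O)c3)n2)cc1Cl`, gives 1800 nM in this assay, and the step of a 2.2-fold higher number from compound 1 to compound 2 (0.34 log units; beyond the scatter) shows that adding fluoro at that position weakened the effect. Among the two measured compounds, compound 2 therefore stands with the highest number, its nearest neighbour being compound 1.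

Compound 3 `COc1cc(OCc2nc(N)nc(Nc3ccc(C)c(Cl)c3)n2)cc(N2CCCC2=O)c1` differs from compound 2 in one place: methoxy in place of fluoro on an aromatic carbon. Among the measured compounds shown here, the only measured step that bears on this position is the one from compound 1 to compound 2, a modest weakening when fluoro entered. For the measured compounds named here, no measured pair shows what methoxy does here, so the direction of the new step cannot be read from the data; a group of a different size and with one more hydrogen-bond acceptor now occupies the site that fluoro occupied. The step is expected to stay close to the scatter, as a 1.2-fold lower number from compound 2 to compound 3 (0.08 log units; within the scatter). For compound 3 the expected value in this assay is 1500 nM, within a range from 500 nM to 4500 nM.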

Compound 3, half-maximal effective concentration: 1800 nM
Estimate against measurement, compound 3: 1.2-fold (0.08 log units) below; low and high end bracket the measured number.
By their numbers in this assay, from the lowest: compound 1; then compounds 2 and 3 (each within the scatter of the next).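

In this assay, methoxy in place of fluoro on this aromatic carbon gives no change at the digits printed from compound 2 to compound 3 (within the scatter), so the larger group, with its hydrogen-bond acceptor, leaves the number where fluoro left it. Measured against the unsubstituted compound, methoxy gives a 2.2-fold higher number from compound 1 to compound 3 (0.34 log units; beyond the scatter), a step of the same printed size as the one for fluoro, a 2.2-fold higher number from compound 1 to compound 2 (0.34 log units; beyond the scatter), which means that in these three compounds both substituents at this position, meta to the 2-oxopyrrolidin-1-yl group, go with a modestly higher number than hydrogen and the two cannot be told apart. Nothing available explains why the two groups give the same result, or why either differs from hydrogen.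

The compounds shown leave open whether an amine, a carboxylic acid or a longer chain such as ethoxy on this carbon would also match fluoro and methoxy, or would move the number away from theirs in either direction. They also leave open whether any group here can give a lower number than hydrogen does, since both substituents shown moved it the same way.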